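The source may hold more compounds than are shown below. What is called first, only, known or untested is meant among the compounds shown, and "the series" means these compounds.

In a physicochemical assay for solubility, read by nephelometry, at pH 7.4 (on this read-out higher numbers stand for higher solubility and lower numbers for lower solubility), compound 1 `COc1cccc(NC(=O)c2nnn(Cc3ccncc3)c2N)c1` gives < 12000 nM, which is a limit of the assay. Compound 2 `COc1cccc(NC(=O)c2nnn(CC3CCN(C(C)=O)CC3)c2N)c1` gives > 250000 nM, also a limit. Within the data shown here, compound 3 `COc1cccc(NC(=O)c2nnn(Cc3ccc(C#N)cc3)c2N)c1` gives 216000 nM, the only actual number of the three. Compound 4 `COc1cccc(NC(=O)c2nnn(Cc3ccc(OC(F)(F)F)cc3)c2N)c1` carries trifluoromethoxy in place of cyano on an aromatic carbon. The measured steps all replace the group on the saturated chain carbon, so they bear on this change only indirectly. Two are large, an at least 20-fold higher number from compound 1 to compound 2 (1.31 log units; beyond the scatter) and an at least 18-fold higher number from compound 1 to compound 3 (1.25 log units; beyond the scatter), while an at least 1.1-fold lower number from compound 2 to compound 3 (0.06 log units; that floor lies within the scatter) has a floor within the scatter. Given the large step of an at least 18-fold higher number from compound 1 to compound 3 (1.25 log units; beyond the scatter), a moderate fall in this assay is expected, estimated as a 3.6-fold lower number from compound 3 to compound 4 (0.56 log units; beyond the scatter). Compound 4 is estimated at 60000 nM, within an expected range of 12000 nM to 200000 nM.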

Compound 4, solubility: 12000 nM
For compound 4 the middle estimate is 5.0-fold (0.70 log units) above the measured one, within the range that was stated.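

In this assay, among these compounds, the aromatic carbon para to a large group proves sensitive in its own right, whereas the earlier steps touched only the group on the saturated chain carbon: trifluoromethoxy in place of cyano gives an 18-fold lower number from compound 3 to compound 4 (1.26 log units; beyond the scatter). Compound 4 thus comes down to the low end of the range shown, where compound 1 stands at a limit: the limit of < 12000 nM in this assay, at which 1 of the 4 values shown sits.

As far as these compounds go, what a methoxy group, a single fluorine, an amine or a carboxylic acid would do on this same carbon stays open. The compounds shown also offer no measured property that would explain the step.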